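The source may hold more compounds than are shown below. What is called first, only, known or untested is meant among the compounds shown, and "the series" means these compounds.

Compound 1 `COc1cccc(Cc2ccnn(CC(=O)Nc3ccc(Br)cc3)c2=O)c1` gives 14600 nM in an assay on HL-60 cells for agonist activity at N-formyl peptide receptor 3 (Homo sapiens), read by calcium flux; on this read-out lower numbers stand for an effect already at smaller amounts and higher numbers for an effect only at larger amounts of compound.
Compound 2 `CCc1cc(Cc2cccc(OC)c2)c(=O)n(CC(=O)Nc2ccc(I)cc2)n1` gives > 50000 nM, which is a limit of the assay rather than a number.
Compound 3 `COc1ccc(Cc2cc(-c3cccs3)nn(CC(=O)Nc3ccc(Br)cc3)c2=O)cc1` gives > 50000 nM, again a limit of the assay rather than a number.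

Compound 3 therefore stands at the upper edge of what this assay can report, and it is not alone there: the limit of > 50000 nM in this assay, at which 2 of the 3 values shown sit. Only compound 1 has a real number, and that number is itself large. Compound 4 `COc1ccc(Cc2cc(-c3ccc(C)cc3)nn(CC(=O)Nc3ccc(Br)cc3)c2=O)cc1` has not been measured. It differs from compound 3 by 4-methylphenyl in place of thiophen-2-yl on an aromatic carbon. Within the data shown here, no measured pair of compounds shares this change, so there is no measured step to lean on. In this assay the step expected is an at least 1.2-fold lower number from compound 3 to compound 4 (0.09 log units; that floor lies within the scatter), with no clear direction beyond the usual scatter. Compound 4 is estimated at 40000 nM, within a range from 12000 nM to 120000 nM.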

Compound 4, half-maximal effective concentration: > 50000 nM
Compound 4: a limit, no number (the forecaster's own chance of this, stated with the estimate: 60%); at least 1.2-fold (0.09 log units) between middle value and limit.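

Compound 3 and compound 4 both end at a limit rather than a number, so no step can be read between them: the limit of > 50000 nM in this assay, at which 3 of the 4 values shown sit.

From the compounds shown here alone, whether 4-methylphenyl and thiophen-2-yl differ at all in this assay stays open.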